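A few compounds are considered here, and "the series" means these few. Any claim that something is new, unique, unknown or untested is made for them only; others in the source may bear on it.

In a physicochemical assay for lipophilicity, at pH 7.4 (on this read-out higher numbers stand for higher lipophilicity and lower numbers for lower lipophilicity), compound 1 (`CNC(=O)c1cc(C(N)=O)cc2c1OC[C@H]2c1ccccc1`) gives 2.7 and compound 2 (`CNC(=O)c1cc(C(N)=O)cc2c1O[C@H](CF)[C@H]2c1ccccc1`) gives 2.9 on the same scale, so the two stand within the usual scatter of each other. Going by the values given here, the only measured step is a number 0.20 log units higher from compound 1 to compound 2 (within the scatter) for fluoromethyl in place of hydrogen on a saturated ring carbon. Compound 3 (`CNC(=O)c1cc(C(=O)N[C@@H]2C[C@H]2C)cc2c1O[C@H](CF)[C@H]2c1ccccc1`) has not yet been measured. It differs from compound 2 at one place, with 2-methylcyclopropyl in place of hydrogen on an amide-type nitrogen. Among the compounds with values here, the measured step concerns another group at another place, so it bears on this change only weakly, and no measured step covers a substitution on that nitrogen. The expectation therefore rests mainly on the size of the entering group, and it points to an upward move beyond the scatter. The expected step is a number 0.70 log units higher from compound 2 to compound 3 (beyond the scatter) on this reading. In this assay the estimated value for compound 3 is 3.6 with an expected range of 3.2 to 4 as the likely span of repeated measurements.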

Compound 3, distribution coefficient: 4.5
Compound 3: middle estimate off by 0.90 log units, on the low side; the whole stated range lies below it.
By their numbers in this assay, from the lowest: compounds 1 and 2 (each within the scatter of the next); then compound 3.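

The amide-type nitrogen proves to be a place where this read-out responds strongly: in this assay, 2-methylcyclopropyl in place of hydrogen, a group of 4 carbon atoms with one three-membered ring and no hydrogen-bond donors or acceptors, gives a number 1.60 log units higher from compound 2 to compound 3 (beyond the scatter). Compound 1 and compound 2 both carry the carbamoyl group unsubstituted. Going by these compounds alone, the earlier compounds could not show this, since their only step, a number 0.20 log units higher from compound 1 to compound 2 (within the scatter), concerns fluoromethyl at another place and says nothing about substitution on that nitrogen. Nothing in the material at hand accounts for the size of the new step, so it stands as an observation for this single pair.

The compounds shown leave open whether the step belongs to 2-methylcyclopropyl in particular, or whether a plain methyl, an unsubstituted cyclopropyl, a longer chain or a chain carrying a hydroxyl or an amine on the same nitrogen would move the number as far. They also leave open whether another stereoisomer of 2-methylcyclopropyl would give a similar value, and whether the same substitution would give a similar step on the core of compound 1, which lacks the fluoromethyl.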